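The source may report more compounds than this note shows. Statements on the series, on what has been measured and on what is new or still open speak of the compounds shown alone.

Compound 1 `C[C@@H]1C[C@@](O)(CC(=O)O)c2cc(F)ccc2O1` was tested in a functional assay on the whole organism (Sciatic nerve) for inhibition, with Rattus norvegicus as the target, with a stated time of 27 h (a higher number here means that more compound is needed for the effect, a lower number that less compound is needed), where compound 1 gives 23 mg/kg. Two further compounds share a different core; how the core of compound 1 differs from the core of compound 2 `Cc1cc2c(cc1Cl)[C@](O)(CC(=O)O)C[C@@H](C)O2` is not broken down here. In this assay compound 2 gives 12.7 mg/kg, and compound 3 `CCc1cc2c(cc1Cl)[C@](O)(CC(=O)O)C[C@@H](C)O2` gives 13.6 mg/kg. Compound 3 carries, relative to compound 2, (methyl in place of hydrogen on a saturated chain carbon bound to an aromatic carbon), and that change gave a 1.1-fold higher number from compound 2 to compound 3 (0.03 log units; within the scatter). Compound 4 `CC[C@@H]1C[C@@](O)(CC(=O)O)c2cc(F)ccc2O1` is not yet measured. It carries, relative to compound 1, (methyl in place of hydrogen on a saturated chain carbon bound to a saturated ring carbon). The two changes are of the same kind, though the place differs: in the one it sits on a saturated chain carbon bound to an aromatic carbon, in the other on a saturated chain carbon bound to a saturated ring carbon. Within this assay the expected step is a 1.1-fold higher number from compound 1 to compound 4 (0.05 log units; within the scatter), resting on the earlier change having given a 1.1-fold higher number from compound 2 to compound 3 (0.03 log units; within the scatter). Compound 4 is therefore expected near 26 mg/kg, with the estimate spanning from 13 mg/kg to 52 mg/kg.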

Compound 4, dose for half-maximal effect: 50.6 mg/kg
Estimate against measurement, compound 4: 1.9-fold (0.29 log units) below; low and high end bracket the measured number.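

In this assay, the methyl in place of hydrogen on a saturated chain carbon bound to a saturated ring carbon gave a 2.2-fold higher number from compound 1 to compound 4 (0.34 log units; beyond the scatter), whereas the change of the same kind on the other core, at a different place, gave a 1.1-fold higher number from compound 2 to compound 3 (0.03 log units; within the scatter). Set side by side, the two steps cannot be told apart: the same change on two cores in this assay, a 1.1-fold higher number (0.03 log units; within the scatter) from compound 2 to compound 3 and a 2.2-fold higher number (0.34 log units; beyond the scatter) from compound 1 to compound 4, 2.1-fold (0.31 log units) apart, within the scatter of two such steps. The pair therefore gives no ground for saying that this change behaves differently on the two cores, but with a single step on each core and the change at a different place in each, it does not show that the change carries over unchanged.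

The compounds shown leave open whether a propyl chain or a phenyl ring at the same place would follow the step seen with the methyl. They also leave open how the same methyl-to-ethyl change would behave at that place on the core of compound 2.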